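Arylpiperazine to acyl piperazine: a furoyl amide variant

A few compounds are considered here, and "the series" means these few. Any claim that something is new, unique, unknown or untested is made for them only; others in the source may bear on it.

Measured compounds:
- compound 1, `COc1ccc(S(=O)(=O)NCCCN2CCN(c3cccc(C(F)(F)F)c3)CC2)cc1`, in an assay on CHO cells for displacement of a labelled ligand from 5-hydroxytryptamine receptor 7 (Homo sapiens) (on this read-out higher numbers stand for weaker inhibition and lower numbers for stronger inhibition), gives 89 nM
- compound 2, `COc1ccc(S(=O)(=O)NCCCN2CCN(c3cccc(OC)c3)CC2)cc1`, in this assay gives 339 nM
- compound 3, `COc1ccc(S(=O)(=O)NCCCN2CCN(C(=O)OCc3ccccc3)CC2)cc1`, in this assay gives only a limit, > 10000 nM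

Compound 3 therefore stands at the weak end of the three numbers shown, and its value is a limit rather than a number, as the limit of > 10000 nM in this assay, at which 1 of the 3 values shown sits, records. The two steps that reach it are both large: an at least 110-fold higher number from compound 1 to compound 3 (2.05 log units; beyond the scatter) and an at least 29-fold higher number from compound 2 to compound 3 (1.46 log units; beyond the scatter). By contrast the change between the two arylpiperazines, a 3.8-fold higher number from compound 1 to compound 2 (0.58 log units; beyond the scatter), is modest.

Compound 4, `COc1ccc(S(=O)(=O)NCCCN2CCN(C(=O)c3ccco3)CC2)cc1`, differs from compound 3 by furan-2-yl in place of benzyloxy on a carbonyl carbon. Within the data shown here, no measured step repeats this exact change. What the measured steps do show is that exchanging an aryl group on the ring nitrogen for a carbonyl-linked group, as in compound 3, carries a large loss. Compound 4 keeps a carbonyl on that nitrogen, so a return toward the numbers of compound 1 or compound 2 is not expected; the expected step is a step that the limit leaves unreadable from compound 3 to compound 4, that is, none beyond the scatter. Compound 4 is therefore estimated at 15000 nM, within 3000 nM to 80000 nM.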

Compound 4, half-maximal inhibitory concentration: > 10000 nM
Compound 4: a limit, no number; the forecaster's own chance of this, stated with the estimate: 75%; the middle value lies beyond the limit too.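

In this assay compound 4 gives only a limit, > 10000 nM, so a second carbonyl-linked group on the ring nitrogen also leaves no number on this read-out: the limit of > 10000 nM in this assay, at which 2 of the 4 values shown sit. The loss is thus not confined to benzyloxycarbonyl, for (furan-2-yl)carbonyl also brings an at least 29-fold higher number from compound 2 to compound 4 (1.46 log units; beyond the scatter) and an at least 110-fold higher number from compound 1 to compound 4 (2.05 log units; beyond the scatter). The step between compound 3 and compound 4 cannot be read, as both values are limits, and the two carbonyl-linked groups cannot be ordered.

The compounds shown leave open whether a benzyl group on the ring nitrogen, with no carbonyl, would restore a measurable value. They also leave open how a phenyl ring carrying a chlorine or a nitrile would compare with the 3-(trifluoromethyl)phenyl of compound 1.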